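A few compounds are considered here, and "the series" means these few. Any claim that something is new, unique, unknown or untested is made for them only; others in the source may bear on it.

The measured compounds and their values:

Compound 1, `Nc1cc(C(F)(F)F)cc2c(=O)cc(N3CCN(CC4CCCCC4)CC3)sc12`, gives 69.4%.
Compound 2, `O=C(OC1CCC(CN2CCN(c3cc(=O)c4cc(C(F)(F)F)cc([N+](=O)[O-])c4s3)CC2)CC1)C1CCCCC1`, gives 1.2%.
Compound 3, `CS(=O)(=O)NC1CCC(CN2CCN(c3cc(=O)c4cc(C(F)(F)F)cc([N+](=O)[O-])c4s3)CC2)CC1`, gives 111%.

These numbers come from an ADME assay on cells (Hepatocyte, Mus musculus) for metabolic stability, with a stated time of 30 min; a lower number here means that less of the compound is left, a higher number that more of the compound is left. Among the three, compound 2 stands lowest, far from compound 1 and furthest from compound 3, both gaps beyond the scatter.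

Compound 4, `O=c1cc(N2CCN(CC3CCC(O)CC3)CC2)sc2c([N+](=O)[O-])cc(C(F)(F)F)cc12`, is not yet measured. It differs from compound 2 in one place: hydrogen in place of cyclohexylcarbonyl on an oxygen on a saturated carbon.

Going by the values given here, only one measured step bears on this change. From compound 2 to compound 3 the same cyclohexylcarbonyl group leaves the saturated ring carbon, there replaced by methanesulfonamido, and the result is a number 109.8 percentage points higher from compound 2 to compound 3 (beyond the scatter). Among the compounds with values here, compound 4 keeps the hydroxy that remains when the cyclohexylcarbonyl is taken away, so it sits closer to compound 2 than compound 3 does, and the single step gives no direct measure of this smaller change. Within the data shown here, still, the one relevant step is large and upward, and compound 1, which also lacks the cyclohexylcarbonyl, stands well above compound 2.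

Compound 4 is therefore expected to show a large upward step in this assay, estimated at 70%, with a range from 35% to 100%. That estimate means an expected step of a number 68.8 percentage points higher from compound 2 to compound 4 (beyond the scatter).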

Compound 4, percent of the compound remaining: 51.2%
Compound 4: the middle estimate sits 18.8 percentage points above what was measured; the range from low to high includes it.
By their numbers in this assay, from the lowest: compound 2; then compound 4; then compound 1; then compound 3.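

In this assay, going by these compounds alone, the hydrogen in place of cyclohexylcarbonyl on the oxygen gives a number 50 percentage points higher from compound 2 to compound 4 (beyond the scatter), which isolates this change for the first time: with only that group gone and the hydroxy left on the saturated ring carbon, a large part of the distance between the two earlier compounds is already covered. The position still separates its groups once the cyclohexylcarbonyl is absent, since hydroxy in place of methanesulfonamido on that same saturated ring carbon gives a number 59.8 percentage points lower from compound 3 to compound 4 (beyond the scatter), so the high number of compound 3 cannot be read as the loss of the (cyclohexylcarbonyl)oxy alone. Nothing available here accounts for either of these steps.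

The compounds shown leave open how an amine, a carboxylic acid or a methoxy on this saturated ring carbon would stand against the hydroxy of compound 4 and the methanesulfonamido of compound 3. They also leave open what a cyclohexyl ring with no such group would give on the core of compound 4, as compound 1 carries that bare ring on a core that differs as well.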